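Isobutoxy to propoxy: a small step in the series

The source may report more compounds than this note shows. Statements on the series, on what has been measured and on what is new or still open speak of the compounds shown alone.

In a functional assay on MCF7 cells (Homo sapiens) for antiproliferative activity, read by sulforhodamine B assay, with a stated time of 3 days (a higher number here means that more compound is needed for the effect, a lower number that less compound is needed), compound 1 (`CCCC1=C(OCC(C)C)C(CCC)(CCC)C(=O)/C(=C(O)\C=C\c2ccccc2)C1=O`) gives 4.4 uM and stands level with compound 2 (`CCCCC1=C(OC)C(CCCC)(CCCC)C(=O)/C(=C(O)\C=C\c2ccccc2)C1=O`), which gives 4.4 uM in the same test. Going by the values given here, these two values lie within the scatter of each other, and they are the only measurements available so far.

Compound 3 (`CCCOC1=C(CCC)C(=O)/C(=C(O)/C=C/c2ccccc2)C(=O)C1(CCC)CCC`) has not yet been measured. It differs from compound 1 by one change (hydrogen in place of methyl on a saturated chain carbon bound to two saturated chain carbons), hydrogen in place of methyl on a saturated chain carbon bound to two saturated chain carbons, so that isobutoxy becomes propoxy.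

Among the compounds with values here, no measured pair isolates a single change, so the evidence for the size of this step is thin. Compound 2 still gives 4.4 uM while differing from compound 1 in more than one place, and this is the sole basis for expecting no step beyond the scatter in this assay and for favouring neither direction. An estimated 1.1-fold higher number from compound 1 to compound 3 (0.04 log units; within the scatter) stays within the scatter. The estimate for compound 3 is 4.8 uM with an expected range from 2.4 uM to 9.5 uM in this estimate.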

Compound 3, concentration for half-maximal effect: 1.6 uM
Compound 3: the middle estimate sits 3.0-fold (0.48 log units) above what was measured, and the stated range ends above it.
By their numbers in this assay, from the lowest: compound 3; then compounds 1 and 2 (each within the scatter of the next).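

Going from isobutoxy to propoxy in this assay gives a 2.8-fold lower number from compound 1 to compound 3 (0.44 log units; beyond the scatter) and is the first step in the series that isolates a single change. It shows that this position is not silent: hydrogen in place of methyl on a saturated chain carbon bound to two saturated chain carbons, a loss of one carbon with no change in hydrogen-bond donors or acceptors, is enough to move the number beyond the scatter, though the step remains modest. Nothing measured in the series bears on why this small change has this effect.

On these data alone, one pair gives a single step and no trend, so it remains open whether a longer straight chain such as butoxy, or a chain ending in an amine or a carboxylic acid, would keep the lower number seen with propoxy. Also open, as far as these compounds go, is whether removing a methyl in the same way on another chain of the shared core would give a step of similar size, or any step at all.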